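Ring Size on the Amine Nitrogen: Compound 3 to Compound 4

The source may hold more compounds than are shown below. What is called first, only, known or untested is meant among the compounds shown, and "the series" means these compounds.

Compound 1, `c1ccc(COc2ccc(OCCOCCNc3ccncc3)cc2)cc1`, gives 20600 nM in a functional assay on SK-OV-3 cells (Homo sapiens) for inhibition, read by CCK-8 assay, with a stated time of 70 h; on this read-out lower numbers stand for stronger inhibition and higher numbers for weaker inhibition.
Compound 2, `OCCOCCOCCOc1ccc(OCc2ccccc2)cc1`, gives 59400 nM in this assay.
Compound 3, `c1ccc(COc2ccc(OCCOCCNC3CCC3)cc2)cc1`, gives 25000 nM in this assay.

Among these three, compound 3 stands second highest. Its nearest neighbour is compound 1, with a 1.2-fold higher number from compound 1 to compound 3 (0.08 log units; within the scatter), a difference within the scatter; its furthest is compound 2, where a 2.4-fold lower number from compound 2 to compound 3 (0.38 log units; beyond the scatter) lies beyond it. Compound 4, `c1ccc(COc2ccc(OCCOCCNC3CC3)cc2)cc1`, is the next compound in this assay. It differs from compound 3 in one place: cyclopropyl in place of cyclobutyl on an amine nitrogen.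

For the measured compounds named here, no measured step swaps one small carbon ring for another. Going by the values given here, the only step that touches the same amine nitrogen is a 1.2-fold higher number from compound 1 to compound 3 (0.08 log units; within the scatter), which stayed within the scatter even though that change was larger than the one at hand. On that basis the step is expected to stay within the scatter as well: no change at the digits printed from compound 3 to compound 4 (within the scatter). Compound 4 is therefore estimated at 25000 nM, with an expected range from 11000 nM to 55000 nM.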

Compound 4, half-maximal inhibitory concentration: 47200 nM
Compound 4: middle estimate off by 1.9-fold (0.28 log units), on the low side; low and high end bracket the measured number.
By their numbers in this assay, from the lowest: compounds 1, 3, 4 and 2 (each within the scatter of the next, the first and the last beyond it).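

In this assay, the change of ring size on the amine nitrogen gives a 1.9-fold higher number from compound 3 to compound 4 (0.28 log units; within the scatter) and so does not separate cyclopropyl from cyclobutyl at this position. Yet cyclopropyl gives the first step beyond the scatter for a replacement of pyridin-4-yl on this nitrogen, with a 2.3-fold higher number from compound 1 to compound 4 (0.36 log units; beyond the scatter) where cyclobutyl gave none, and a 1.3-fold lower number from compound 2 to compound 4 (0.10 log units; within the scatter) leaves cyclopropylamino inseparable from the 2-hydroxyethoxy end of compound 2, which cyclobutylamino was not. Nothing available explains these results.

The compounds shown leave open whether a larger carbon ring on this nitrogen, such as cyclopentyl or cyclohexyl, would give a step beyond the scatter from compound 3. They also leave open how an open chain such as isopropyl would compare with these small rings.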